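A few compounds are considered here, and "the series" means these few. Any claim that something is new, unique, unknown or untested is made for them only; others in the source may bear on it.

Measured in a functional assay on MCF7 cells (Homo sapiens) for antiproliferative activity, with a stated time of 5 days; a lower number here means a stronger inhibitor, a higher number a weaker inhibitor:
- Compound 1 `CCCCc1ccc2[nH]c(-c3ccc(OC)cc3)c(/C=N/NC(=O)c3ccc(F)cc3)c2c1`: 84 nM
- Compound 2 `CCCCc1ccc2[nH]c(-c3ccc(C(F)(F)F)cc3)c(/C=N/NC(=O)c3ccc(OC)cc3)c2c1`: 618 nM
- Compound 3 `CCCCc1ccc2[nH]c(-c3ccc(OC)cc3)c(/C=N/NC(=O)c3ccccc3OC)c2c1`: 71 nM

Compound 3, at 71 nM, sits level with compound 1 within the scatter and well under compound 2. Compound 4 `CCCCc1ccc2[nH]c(-c3ccc(OC)cc3)c(/C=N/NC(=O)c3cccnc3)c2c1` keeps the shared core of compound 3 but carries pyridin-3-yl in place of 2-methoxyphenyl on a carbonyl carbon.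

Going by the values given here, only one measured step bears on this change. It is a swap on the same carbonyl carbon, 2-methoxyphenyl in place of 4-fluorophenyl, and it gives a 1.2-fold lower number from compound 1 to compound 3 (0.07 log units; within the scatter). Compound 2 differs from compound 3 in more than one place, so it cannot isolate this group. Among the compounds with values here, no measured compound carries pyridin-3-yl, which leaves the direction open and the range wide. A change beyond the scatter in this assay is therefore not expected.

The expected step is a 1.4-fold higher number from compound 3 to compound 4 (0.15 log units; within the scatter).

For compound 4 the estimated value is 100 nM, with an expected range from 35 nM to 300 nM.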

Compound 4, half-maximal inhibitory concentration: 75 nM
Compound 4: the middle estimate sits 1.3-fold (0.12 log units) above what was measured; the measured number falls inside the stated range.
By their numbers in this assay, from the lowest: compounds 3, 4 and 1 (each within the scatter of the next); then compound 2.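

In this assay, swapping the group on the carbonyl carbon for pyridin-3-yl gives a 1.1-fold higher number from compound 3 to compound 4 (0.02 log units; within the scatter), and a 1.1-fold lower number from compound 1 to compound 4 (0.05 log units; within the scatter). Until now this place had shown only six-membered aromatic rings of carbon, so this is the first sign that a ring with a hetero atom, and with fewer heavy atoms than 2-methoxyphenyl, leaves the number within the scatter: compounds 1, 3 and 4 all sit level. Nothing measured here explains why the number holds steady.

Still open, going by these compounds, is whether that holds for a group without an aromatic ring on the carbonyl carbon, such as a piperidine or a longer alkyl chain. Compound 2 differs from these compounds in more than one place, so it cannot show whether pyridin-3-yl would behave the same way on its core.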